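A few compounds are considered here, and "the series" means these few. Any claim that something is new, unique, unknown or untested is made for them only; others in the source may bear on it.

Compound 1, with the structure `COc1ccc([C@H](C)N(Cc2ccc(C(C)(C)C)cc2)Cc2cc3cc(OC)ccc3[nH]c2=O)cc1`, is tolerated at 4100 nM in a toxicity assay on MDCK cells (Canis lupus familiaris) for cytotoxicity, read by crystal violet staining, with a stated time of 48 h; a higher number here means that more compound is tolerated, a lower number that less compound is tolerated. Of the two numbers shown it is the lower one. Compound 2, with the structure `COc1ccc2[nH]c(=O)c(CN(Cc3ccc(N(C)C)cc3)Cc3ccc(C(C)(C)C)cc3)cc2c1`, gives 8500 nM in this assay, and the step is a 2.1-fold higher number from compound 1 to compound 2 (0.32 log units; beyond the scatter). Compound 3, with the structure `COc1ccc2[nH]c(=O)c(CN(Cc3ccc(C(C)(C)C)cc3)Cc3ccc(C(F)(F)F)c(Cl)c3)cc2c1`, reaches only the limit of this assay, > 10000 nM. That is the limit of > 10000 nM in this assay, at which 1 of the 3 values shown sits.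

Compound 4, with the structure `COc1ccc([C@H](C)N(Cc2ccc(C(C)(C)C)cc2)Cc2cc3cc(C4CC4)ccc3[nH]c2=O)cc1`, differs from compound 1 in one place: cyclopropyl in place of methoxy on an aromatic carbon. Every measured step changes a different place, the group carried by the amine nitrogen: a 2.1-fold higher number from compound 1 to compound 2 (0.32 log units; beyond the scatter), an at least 2.4-fold higher number from compound 1 to compound 3 (0.38 log units; beyond the scatter), and an at least 1.1-fold higher number from compound 2 to compound 3 (0.07 log units; that floor lies within the scatter). Going by the values given here, no measured step touches the aromatic carbon of the shared core where methoxy gives way to cyclopropyl, so none bears directly on this change, and no step beyond the scatter is expected in this assay in either direction. The expected step is a 1.0-fold lower number from compound 1 to compound 4 (0.01 log units; within the scatter). Compound 4 is estimated at 4000 nM, within a range from 1500 nM to 10000 nM.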

Compound 4, half-maximal cytotoxic concentration: > 10000 nM
Compound 4 was reported as a limit; the forecaster's own chance of this, stated with the estimate: 15%; middle value at least 2.5-fold (0.39 log units) from the limit.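

Moving away from methoxy at this aromatic carbon of the shared core matters in this assay: cyclopropyl there gives an at least 2.4-fold higher number from compound 1 to compound 4 (0.38 log units; beyond the scatter). Going by these compounds alone, the earlier steps all changed the group on the amine nitrogen, so this is the first sign that the core position can also shift how much compound the cells tolerate, and the shift runs the same way as those steps from compound 1. The reading for compound 4 is a limit and not a number, so the true size of this step stays unknown: the limit of > 10000 nM in this assay, at which 2 of the 4 values shown sit.

One swap cannot tell whether this belongs to cyclopropyl alone, or whether an ethyl group, a chlorine or an amine on the same carbon would do the same. As far as these compounds go, it also remains open whether cyclopropyl acts alike with other groups on the amine nitrogen, such as the 4-(dimethylamino)benzyl of compound 2.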